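Chloro Added to the Benzyl Arm of an Amide Analogue

The source may hold more compounds than are shown below. What is called first, only, known or untested is meant among the compounds shown, and "the series" means these compounds.

Compound 1 `CCOC(=O)c1oc2ccc(N(Cc3ccc(Cl)cc3)S(=O)(=O)c3ccc(Cl)cc3)cc2c1C`: 9480 nM
Compound 2 `Cc1c(C(=O)NCCCn2ccnc2)oc2ccc(N(Cc3ccccc3)S(=O)(=O)c3ccc(Cl)cc3)cc12`: 17100 nM

In a functional assay on HCT-116 cells (Homo sapiens) for inhibition, read by MTT assay, with a stated time of 72 h (on this read-out higher numbers stand for weaker inhibition and lower numbers for stronger inhibition), compound 1 gives 9480 nM and compound 2 gives 17100 nM. Compound 2 sits at the upper of the two numbers, but its gap to compound 1 lies within the scatter, so no order between them can be claimed. Compound 3 `Cc1c(C(=O)NCCCn2ccnc2)oc2ccc(N(Cc3ccc(Cl)cc3)S(=O)(=O)c3ccc(Cl)cc3)cc12` differs from compound 2 by chloro in place of hydrogen on an aromatic carbon. For the measured compounds named here, no measured pair isolates this change, so the step is expected to stay within the scatter, a 1.4-fold lower number from compound 2 to compound 3 (0.15 log units; within the scatter). Compound 3 is therefore expected to give 12000 nM, between 4000 nM and 35000 nM.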

Compound 3, half-maximal inhibitory concentration: 2430 nM
Compound 3: middle estimate off by 4.9-fold (0.69 log units), on the high side; the whole stated range lies above it.
By their numbers in this assay, from the lowest: compound 3; then compounds 1 and 2 (each within the scatter of the next).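

In this assay, for the compounds shown here, replacing hydrogen with chloro on the benzyl arm gives a 7.0-fold lower number from compound 2 to compound 3 (0.85 log units; beyond the scatter) and so provides the first single-change reading at this position, where the arm goes from benzyl to 4-chlorobenzyl. With the 4-chlorobenzyl arm held constant, placing (3-(1H-imidazol-1-yl)propyl)amino in place of ethoxy on the carbonyl carbon gives a 3.9-fold lower number from compound 1 to compound 3 (0.59 log units; beyond the scatter) as a second step beyond the scatter. Nothing available explains either step.

On these data alone, whether fluoro, bromo or methoxy at this position would give a similar step remains open. So does whether a shorter chain or a morpholine in place of the imidazole would preserve the lower number seen for compound 3.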